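Replacing furan-2-yl with 5-bromo-2-hydroxyphenyl: notes on compound 3

A few compounds are considered here, and "the series" means these few. Any claim that something is new, unique, unknown or untested is made for them only; others in the source may bear on it.

Two members of the series have been measured so far. Within the data shown here, in a functional assay on MGC-803 cells (Homo sapiens) for antiproliferative activity, read by MTT assay, with a stated time of 72 h (a lower number here means a stronger inhibitor, a higher number a weaker inhibitor), compound 1 `C/C(=N\NC(=O)c1cccc(S(=O)(=O)N2CCOCC2)c1)c1cc(O)ccc1O` gives 9090 nM, the only actual number available.

Compound 2 `O=C(N/N=C/c1ccco1)c1cccc(S(=O)(=O)N2CCOCC2)c1` gives > 100000 nM, which is a limit of the assay and not a number. Compound 2 thus stands at the limit of > 100000 nM in this assay, at which 1 of the 2 values shown sits.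

Compound 3 `O=C(N/N=C/c1cc(Br)ccc1O)c1cccc(S(=O)(=O)N2CCOCC2)c1` keeps the shared core of compound 2 and carries 5-bromo-2-hydroxyphenyl in place of furan-2-yl on a carbon with a double bond to nitrogen. Among the measured compounds shown here, no step between measured compounds is available to size this change, so any expectation is loose.

In this assay, a shift toward stronger inhibition, beyond the scatter, is expected. The expectation leans on compound 1, which has no furan-2-yl group and gives 9090 nM. The estimated step of an at least 6.6-fold lower number from compound 2 to compound 3 (0.82 log units; beyond the scatter) is large, but its size stays uncertain while one end is only a limit.

For compound 3, the estimated value is 15000 nM, with an expected range of 3000 nM to 70000 nM.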

Compound 3, half-maximal inhibitory concentration: 14800 nM
The estimate for compound 3 lay 1.0-fold (0.01 log units) above the measured number; measured number inside the range.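

In this assay, among these compounds, the step at the carbon with a double bond to nitrogen is the first that can be read, and it is beyond the scatter: an at least 6.7-fold lower number from compound 2 to compound 3 (0.82 log units; beyond the scatter). This reading gives only a bound on the size of the step, as the end at compound 2 is a limit of the assay and not a number: the limit of > 100000 nM in this assay, at which 1 of the 3 values shown sits.

With 5-bromo-2-hydroxyphenyl on this carbon, compound 3 gives 14800 nM, so the group at this place can yield an actual number, at least for this one exchange.

Among the compounds shown here, still open is which part of the exchange carries the step: the six-membered aromatic ring of carbon only, the bromine or the hydroxy group, all of which enter together, while compound 1 differs from compound 3 in more than one place and offers no step to separate them. From the compounds shown here alone, how a plain phenyl group, with neither bromine nor hydroxy, would read on this carbon in this assay remains unknown.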